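A thiophene exchange on compound 1

The compounds below may be only part of what the source reports. "The series", "measured", "known", "first", "only" and "open" are said of these compounds alone.

In a functional assay on HUVEC cells (Homo sapiens), read by BrdU incorporation, with a stated time of 72 h (a lower number here means a stronger inhibitor, a higher number a weaker inhibitor), compound 1 (`Cc1ccc2nc(Cl)c(/C=C/C(=O)c3cc(Cl)sc3Cl)cc2c1`) gives 26.2 nM and holds the lower of two numbers. Compound 2 (`Cc1cccc2cc(/C=C/C(=O)c3ccc(Cl)s3)c(Cl)nc12`) gives the higher number (116 nM), a gap beyond the scatter. Compound 3 (`Cc1ccc2nc(Cl)c(/C=C/C(=O)c3ccc(C)s3)cc2c1`) keeps the core of compound 1 and carries 5-methylthiophen-2-yl in place of 2,5-dichlorothiophen-3-yl on a carbonyl carbon. For the measured compounds named here, no measured pair shows this change alone, so the guide is thin. A weaker result beyond the scatter is expected in this assay for this exchange (a 3.4-fold higher number from compound 1 to compound 3 (0.54 log units; beyond the scatter)). For compound 3 the estimate is 90 nM (expected range 25 nM to 320 nM).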

Compound 3, half-maximal inhibitory concentration: 128 nM
The estimate for compound 3 lay 1.4-fold (0.15 log units) below the measured number; measured number inside the range.
By their numbers in this assay, from the lowest: compound 1; then compounds 2 and 3 (each within the scatter of the next).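

In this assay, for the compounds shown here, this exchange gives the first direct reading at this position: 5-methylthiophen-2-yl in place of 2,5-dichlorothiophen-3-yl on a carbonyl carbon weakens inhibition, with a 4.9-fold higher number from compound 1 to compound 3 (0.69 log units; beyond the scatter). The core of compound 1 stays unchanged, so the loss belongs to the exchange as a whole. Nothing available explains the loss. The exchange alters the point of attachment, the chlorines and the methyl together, so their shares cannot be separated. From the compounds shown here alone, whether 5-chlorothiophen-2-yl or plain thiophen-2-yl on this core would restore inhibition remains open.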